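Aryl hydrazone variation on the shared core

A few compounds are considered here, and "the series" means these few. Any claim that something is new, unique, unknown or untested is made for them only; others in the source may bear on it.

Of the compounds shown here, two carry numbers so far. Compound 1 `Cn1c(=O)c(=O)n(C2CCCC2)c2nc(N/N=C/c3cccs3)ncc21` bears thiophen-2-yl on the carbon with a double bond to nitrogen; in a functional assay on PC-3 cells (Homo sapiens) for antiproliferative activity, read by MTT assay (on this read-out lower numbers stand for stronger inhibition and higher numbers for weaker inhibition), compound 1 gives 75600 nM, the higher of the two numbers. Compound 2 `Cn1c(=O)c(=O)n(C2CCCC2)c2nc(N/N=C/c3cc(C(F)(F)F)cc(C(F)(F)F)c3)ncc21` carries a different aryl group at that place; in this assay compound 2 gives 8200 nM, a markedly lower number than compound 1, well beyond the usual scatter.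

Compound 3 `Cn1c(=O)c(=O)n(C2CCCC2)c2nc(N/N=C/c3ccccc3Cl)ncc21` has not yet been measured. Relative to compound 1 the change is 2-chlorophenyl in place of thiophen-2-yl on a carbon with a double bond to nitrogen. Among the measured compounds shown here, no measured pair isolates this change, so the expectation rests on compound 1 and compound 2 alone. The step from compound 1 is expected to run toward lower numbers, moderately beyond the scatter, as a 3.8-fold lower number from compound 1 to compound 3 (0.58 log units; beyond the scatter), because compound 2 gives 8200 nM. Compound 3 is expected to give 20000 nM, within a range from 6000 nM to 60000 nM.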

Compound 3, half-maximal inhibitory concentration: 16300 nM
For compound 3 the middle estimate is 1.2-fold (0.09 log units) above the measured one; measured number inside the range.
By their numbers in this assay, from the lowest: compounds 2 and 3 (each within the scatter of the next); then compound 1.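

In this assay, 2-chlorophenyl in place of thiophen-2-yl on the carbon with a double bond to nitrogen gives a 4.6-fold lower number from compound 1 to compound 3 (0.67 log units; beyond the scatter) and so shows that this position responds to a change of aryl group with a single chlorine on the ring. Compound 3 lies within the usual scatter of compound 2, so a number well under that of compound 1 is not confined to the aryl group of compound 2. Nothing in hand gives a reason for this step.

Whether the step follows the chlorine or the six-membered ring stays open, since plain phenyl is not among the compounds shown. Going by these compounds, an aryl group carrying an amine or a carboxylic acid, and a longer chain on the shared core, also remain open.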